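Moving the chlorine on the anilino ring: compound 4

The source may hold more compounds than are shown below. What is called first, only, known or untested is meant among the compounds shown, and "the series" means these compounds.

Compound 3 `CN1CCN(CC(=O)Nc2ccc3ncnc(Nc4cccc(Cl)c4)c3c2)CC1` is tested in a functional assay on MCF7 cells (Homo sapiens) for antiproliferative activity, read by MTT assay, with a stated time of 48 h; on this read-out lower numbers stand for stronger inhibition and higher numbers for weaker inhibition. Compound 3 gives > 100000 nM, which is a limit and not a number. Compound 2 `O=C(CN1CCCCC1)Nc1ccc2ncnc(Nc3cccc(Cl)c3)c2c1` likewise gives > 100000 nM, a limit. Compound 1 `O=C(CN1CCCCC1)Nc1ccc2ncnc(Nc3cccc(C(F)(F)F)c3)c2c1` gives > 100000 nM, also a limit. All three sit at the limit of > 100000 nM in this assay, at which 3 of the 3 values shown sit. The step from compound 1 to compound 2 reads a step that the two limits leave unreadable from compound 1 to compound 2, and the step from compound 2 to compound 3 reads a step that the two limits leave unreadable from compound 2 to compound 3; neither has a readable size. Compound 4 `CN1CCN(CC(=O)Nc2ccc3ncnc(Nc4ccc(Cl)cc4)c3c2)CC1` differs from compound 3 by 4-chlorophenyl in place of 3-chlorophenyl on a nitrogen on an aromatic ring. Within the data shown here, no measured step bears directly on this change. The step of a number no higher from compound 3 to compound 4 (the limit leaves the size open) is expected to show nothing beyond the scatter. Compound 4 is therefore estimated at 100000 nM, with a range from 30000 nM to 300000 nM, most likely again only a limit.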

Compound 4, half-maximal inhibitory concentration: 15000 nM
Compound 4: middle estimate off by 6.7-fold (0.82 log units), on the high side; measured number outside the range, below it.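

In this assay, 4-chlorophenyl in place of 3-chlorophenyl on a nitrogen on an aromatic ring gives an at least 6.6-fold lower number from compound 3 to compound 4 (0.82 log units; beyond the scatter). Among these compounds, this is the first step with a readable direction, as the earlier steps cannot be read. Compounds 3 and 4 have the same atoms, so the place of the chlorine on this ring is enough to bring compound 4 off the limit: the limit of > 100000 nM in this assay, at which 3 of the 4 values shown sit.

From the compounds shown here alone, whether 4-chlorophenyl has the same effect alongside piperidin-1-yl remains open. So does whether a 4-fluorophenyl or 4-methoxyphenyl group on this nitrogen would give a lower number still.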